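Ethoxy in Place of Methyl: An Expected Shift

A few compounds are considered here, and "the series" means these few. Any claim that something is new, unique, unknown or untested is made for them only; others in the source may bear on it.

Compound 1 `Cc1ccc(Cc2ccc3ccccc3c2O)cc1` is the strongest of three compounds tested in an assay on RBL-1 cells with Polyunsaturated fatty acid 5-lipoxygenase (Rattus norvegicus) as the target (on this read-out lower numbers stand for stronger inhibition and higher numbers for weaker inhibition), where compound 1 gives 24 nM. Compound 3 `COc1cccc(Cc2ccc3ccccc3c2O)c1` gives 110 nM in this assay, and compound 2 `Oc1c(Cc2cccnc2)ccc2ccccc12` gives 230 nM; both gaps to compound 1 lie beyond the scatter. Compound 4 `CCOc1ccc(Cc2ccc3ccccc3c2O)cc1` has not yet been measured. It differs from compound 1 in one place: ethoxy in place of methyl on an aromatic carbon. Among the measured compounds shown here, no step between measured compounds isolates this change, so the expectation rests on the spread of the three values. A modest loss is expected, because in this assay compound 3 gives 110 nM after a different change to the same ring. The step from compound 1 to compound 4 is estimated at a 2.1-fold higher number from compound 1 to compound 4 (0.32 log units; beyond the scatter). Compound 4 is expected to give 50 nM, within 15 nM to 170 nM.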

Compound 4, half-maximal inhibitory concentration: 62 nM
Beside the measured number, compound 4's estimate is 1.2-fold (0.09 log units) below it; the range from low to high includes it.
By their numbers in this assay, from the lowest: compound 1; then compounds 4 and 3 (each within the scatter of the next); then compound 2.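

Ethoxy in place of methyl on this aromatic carbon gives a 2.6-fold higher number from compound 1 to compound 4 (0.41 log units; beyond the scatter), the first reading of a single change at this position. The step is modest, so this position accepts the larger ethoxy group, with its added oxygen, at the price of only a limited loss of inhibition. Nothing available explains why the number rises.

The compounds shown cannot separate the part played by the oxygen from that of the added length. On these data alone, how a propyl chain, an amine or a carboxylic acid would fare at this position also remains open.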